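The source may hold more compounds than are shown below. What is called first, only, known or untested is meant among the compounds shown, and "the series" means these compounds.

Compound 1 `O=C(Nc1ccccc1)Oc1ccc(Cl)cc1C(=O)Nc1ccc(F)cc1`: > 20000 nM
Compound 2 `O=C(NCc1ccccc1)Oc1ccc(Cl)cc1`: > 125000 nM

Two compounds have been examined in an ADME assay on HepG2 cells (Homo sapiens) for cytotoxicity, read by MTT assay; on this read-out lower numbers stand for stronger inhibition and higher numbers for weaker inhibition. Compound 1 shows only a limit of the test, > 20000 nM, rather than a number. Compound 2 likewise gives only a limit, > 125000 nM. Among the measured compounds shown here, neither result is a true measurement, so no step between them can be counted; both values simply say that cytotoxicity, if present, lies beyond what the test could resolve. The limit for compound 1 is recorded as the limit of > 20000 nM in this assay, at which 1 of the 2 values shown sits, and the limit for compound 2 as the limit of > 125000 nM in this assay, at which 1 of the 2 values shown sits.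

Compound 3 `O=C(Nc1ccccc1)Oc1ccc(Cl)cc1C(=O)Nc1ccc(C(F)(F)F)cc1` has not yet been tested in this assay. It differs from compound 1 in a single spot: trifluoromethyl in place of fluoro on an aromatic carbon. Fluoro leaves and trifluoromethyl enters, with the rest of the structure, including the shared core, kept unchanged.

Given that compound 1 sits at a limit with no cytotoxicity resolved, the step from compound 1 to compound 3 is expected to be small or absent, and compound 3 is expected to fall again near or beyond the same limit, at an estimated 40000 nM with a range from 15000 nM to 150000 nM, meaning an expected step that the limit leaves unreadable from compound 1 to compound 3.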

Compound 3, half-maximal inhibitory concentration: 9800 nM
Estimate against measurement, compound 3: 4.1-fold (0.61 log units) above; measured number below the stated range.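

In this assay, compound 3 is the first compound shown with a true number rather than a limit, so this position on the aromatic ring can carry a change that brings cytotoxicity into the range the test can read. Putting trifluoromethyl in place of fluoro, the change from 4-fluorophenyl to 4-(trifluoromethyl)phenyl, gives an at least 2.0-fold lower number from compound 1 to compound 3 (0.30 log units; that floor lies within the scatter). This step is only a floor, and its true size stays unknown because compound 1 has a limit and not a number: the limit of > 20000 nM in this assay, at which 1 of the 3 values shown sits.

The compounds shown leave open how a chloro group, a methoxy group or a nitrile at the same place would read in this assay, so it cannot yet be said whether the change in read-out is special to trifluoromethyl or would appear with other groups as well. They also leave open whether the same swap of fluoro for trifluoromethyl would give a readable number on a core other than the shared core of compound 1 and compound 3.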